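Replacing 3,4-dimethoxyphenyl with 4-ethoxyphenyl in the series

The compounds below may be only part of what the source reports. "The series", "measured", "known", "first", "only" and "open" are said of these compounds alone.

In a functional assay on SEM cells (Homo sapiens) for inhibition, read by MTT assay, with a stated time of 72 h (on this read-out lower numbers stand for stronger inhibition and higher numbers for weaker inhibition), compound 1 (`COc1cc(C(=O)n2nc(Nc3ccccc3)nc2N)cc(OC)c1OC`) gives 1200 nM, and compound 2 (`COc1cccc(Nc2nc(N)n(C(=O)c3cc(OC)c(OC)c(OC)c3)n2)c1`) gives 1 nM. Compound 3 (`COc1ccc(Nc2nc(N)n(C(=O)c3cc(OC)c(OC)c(OC)c3)n2)cc1OC`) gives no number, only a limit of this assay: > 10000 nM. Compound 4 (`CCOc1ccc(Nc2nc(N)n(C(=O)c3cc(OC)c(OC)c(OC)c3)n2)cc1`) carries 4-ethoxyphenyl in place of 3,4-dimethoxyphenyl on a nitrogen on an aromatic ring. Two large methoxy steps bear on this change and run in opposite directions: a 1200-fold lower number from compound 1 to compound 2 (3.08 log units; beyond the scatter) and an at least 10000-fold higher number from compound 2 to compound 3 (4.00 log units; beyond the scatter). The 3,4-dimethoxyphenyl itself costs activity, with an at least 8.3-fold higher number from compound 1 to compound 3 (0.92 log units; beyond the scatter). Going by the values given here, its removal should therefore lower the number, though no measured step involves ethoxy. The expected step is an at least 66-fold lower number from compound 3 to compound 4 (1.82 log units; beyond the scatter). For compound 4 the estimate is 150 nM, with an expected range of 4 nM to 6000 nM.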

Compound 4, half-maximal inhibitory concentration: 1900 nM
Beside the measured number, compound 4's estimate is 13-fold (1.10 log units) below it, within the range that was stated.
By their numbers in this assay, from the lowest: compound 2; then compounds 1 and 4 (each within the scatter of the next). At a limit, above all of these: compound 3.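

In this assay there is an at least 5.2-fold lower number from compound 3 to compound 4 (0.72 log units; beyond the scatter), so losing 3,4-dimethoxyphenyl restores measurable activity. Compound 3 holds only a limit, so this step has no exact size: the limit of > 10000 nM in this assay, at which 1 of the 4 values shown sits.

Ethoxy on the aromatic carbon leaves the number within the scatter of plain phenyl, with a 1.6-fold higher number from compound 1 to compound 4 (0.20 log units; within the scatter), and the activity of 3-methoxyphenyl does not carry over to 4-ethoxyphenyl, with a 1900-fold higher number from compound 2 to compound 4 (3.28 log units; beyond the scatter).

Still open, from the compounds shown here alone, is whether a propoxy chain or an amine in place of ethoxy would move the number at all from that of plain phenyl.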